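The source may hold more compounds than are shown below. What is called first, only, known or untested is meant among the compounds shown, and "the series" means these compounds.

Values in a functional assay on PC-3 cells (Homo sapiens) for inhibition, read by sulforhodamine B assay; on this read-out higher numbers stand for weaker inhibition of growth and lower numbers for stronger inhibition of growth:
- compound 1 `Cc1ccc2[nH]c(-c3ccc(-c4ccc(-c5ccc(N(C)C)cc5)cc4)cc3)nc2c1`: 8120 nM
- compound 2 `Cc1ccc2[nH]c(-c3ccc(-c4ccc(-c5cccc(Cl)c5)cc4)cc3)nc2c1`: 2670 nM
- compound 3 `Cc1ccc2[nH]c(-c3ccc(-c4ccc(-c5ccccc5)cc4)cc3)nc2c1`: 100000 nM

In this assay, compound 3 has the highest number of the three and is the weakest, with both of its steps to the others beyond the scatter. The next compound, compound 4 `Cc1ccc2[nH]c(-c3ccc(-c4ccc(-c5ccc(F)cc5)cc4)cc3)nc2c1`, puts fluoro in place of hydrogen on compound 3, on an aromatic carbon of a six-membered aromatic ring of carbon only, para to a large group: fluoro in place of hydrogen on an aromatic carbon.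

For the measured compounds named here, two measured steps bear on this change, and both are large. Replacing dimethylamino with hydrogen gives a 12-fold higher number from compound 1 to compound 3 (1.09 log units; beyond the scatter), and replacing chloro with hydrogen gives a 37-fold higher number from compound 2 to compound 3 (1.57 log units; beyond the scatter). Read backwards, each says that a substituent on this otherwise bare phenyl goes with a lower number, and none of the three compounds goes against that. The two substituted compounds are also much closer to each other, at a 3.0-fold lower number from compound 1 to compound 2 (0.48 log units; beyond the scatter), than either is to compound 3. Fluoro itself has not been measured in this series, so the size of its step is uncertain, and a large drop is expected rather than known.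

The expected change is a 13-fold lower number from compound 3 to compound 4 (1.10 log units; beyond the scatter), towards stronger inhibition of growth. The estimate for compound 4 is 8000 nM, with an expected range of 2000 nM to 60000 nM.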

Compound 4, concentration for 50% growth inhibition: 100000 nM
For compound 4 the middle estimate is 13-fold (1.10 log units) below the measured one, outside the stated range (above it).
By their numbers in this assay, from the lowest: compound 2; then compound 1; then compounds 3 and 4 (each within the scatter of the next).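

In this assay, fluoro in the place para to a large group does not behave like the other substituents (no change at the digits printed from compound 3 to compound 4 (within the scatter)), so the earlier reading, that any substituent on this phenyl goes with a lower number, fails at compound 4. The change from phenyl to 4-fluorophenyl leaves compound 4 well apart from both substituted compounds (a 37-fold higher number from compound 2 to compound 4 (1.57 log units; beyond the scatter); a 12-fold higher number from compound 1 to compound 4 (1.09 log units; beyond the scatter)), so what counts at this ring is the particular group and not merely the presence of one. Nothing measured here accounts for the difference between fluoro and dimethylamino at this place.

Still open, from the compounds shown here alone, is whether the lower number of compound 2 belongs to chloro itself or to its place on the ring, a question that 4-chlorophenyl and 3-fluorophenyl analogues would separate. Also open, going by these compounds, is whether dimethylamino is needed in full at this place or whether a primary amine, a methoxy group or a carboxylic acid would also give a number lower than that of compound 3.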